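A few compounds are considered here, and "the series" means these few. Any claim that something is new, unique, unknown or untested is made for them only; others in the source may bear on it.

Compound 2, whose structure is `COc1cc(C(c2ccc(O)c(OC)c2)[C@H](CF)C(C)C)ccc1O`, is the starting point here. Going by the values given here, in a functional assay on HeLa cells (Homo sapiens) for cytotoxicity, read by WST assay, with a stated time of 48 h (a higher number here means a weaker inhibitor, a lower number a stronger inhibitor), compound 2 gives 19000 nM, and this is the only actual number among the values known so far. The other compound with a result, compound 1 with the structure `COc1ccc(C(c2ccc(OC)c(OC)c2)[C@@H](C)[C@H](C)CO)cc1OC`, reached only a limit of the assay. In this assay compound 1 gives > 100000 nM, which is a limit rather than a measured number, a point made clear by the limit of > 100000 nM in this assay, at which 1 of the 2 values shown sits.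

The compound still to be tested is compound 3, with the structure `CCCCC[C@H](C(C)C)C(c1ccc(O)c(OC)c1)c1ccc(O)c(OC)c1`. Set against compound 2, the change is a single one: butyl in place of fluoro on a saturated chain carbon, three bonds along the chain from two aromatic carbons. Among the compounds with values here, no measured pair in this set differs by exactly this kind of exchange, so there is no direct precedent to lean on, and the two compounds already measured tell only that compound 2 sits inside the measurable range while compound 1 does not.

My expectation is a step from compound 2 to compound 3 of a 1.9-fold lower number from compound 2 to compound 3 (0.28 log units; within the scatter), a modest gain that may or may not exceed the scatter. For compound 3 I therefore estimate 10000 nM, with a plausible range from 3000 nM to 40000 nM.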

Compound 3, half-maximal inhibitory concentration: 9200 nM
The estimate for compound 3 lay 1.1-fold (0.04 log units) above the measured number; measured number inside the range.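

In this assay, butyl in place of fluoro on a saturated chain carbon, three bonds along the chain from two aromatic carbons, gives a 2.1-fold lower number from compound 2 to compound 3 (0.31 log units; beyond the scatter), a modest step that lies just beyond the usual scatter. Going by these compounds alone, this is the first direct reading at this position, and it shows that the position tolerates far more than a single atom: butyl, with its 4 carbon atoms, replaces 1 fluorine, and the number does not rise but falls slightly, staying well inside the measurable range. The values shown record how far the number moved but offer nothing that accounts for the move, so this single pair gives the size of the change and not its cause.

A single exchange cannot show whether the number would keep falling as the chain grows, so a longer chain such as octyl, or a shorter one such as ethyl, remains an open question at this position. Also open is how this position would respond to a chain ending in an amine or a carboxylic acid, since both groups shown here, fluoro and butyl, carry no hydrogen-bond donors or acceptors and no net charge.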